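This account rests on a few compounds, and the source may have more. Where it says the series, first, only, none or still open, it means among the compounds named here.

Working notes on the series. The shared core is that of compound 1 `CCCCCn1c(CCC)nc2cc(NS(C)(=O)=O)ccc21`, which in a functional assay on the whole organism with Rattus norvegicus as the target, read by paw edema, with a stated time of 5 h, at a dose of 2.5 mg/kg by the oral route (on this read-out higher numbers stand for a stronger effect at the one dose given and lower numbers for a weaker effect), gives 48.2%. Compound 2 `CCCCCCn1c(CCC)nc2cc(NS(C)(=O)=O)ccc21` carries the longer chain on the aromatic nitrogen; in this assay compound 2 gives 50.2%. Going by the values given here, of the two numbers measured so far, the one for compound 2 is the larger, but only by a number 2 percentage points higher from compound 1 to compound 2 (within the scatter), so the two values sit within the scatter of each other and no ranking between them is supported.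

Compound 3 `CCCCn1c(CCC)nc2cc(NS(C)(=O)=O)ccc21` has not yet been measured. It differs from compound 2 by hydrogen in place of ethyl on a saturated chain carbon, four bonds along the chain from an aromatic nitrogen. Among the compounds with values here, the only measured step that bears on this change is the one along the same chain, a number 2 percentage points higher from compound 1 to compound 2 (within the scatter), which stayed within the scatter. Removing the ethyl goes in the opposite direction and further than that step, so the evidence is thin; on what is shown, no step beyond the scatter is expected in this assay, a number 2.2 percentage points lower from compound 2 to compound 3 (within the scatter). Compound 3 is accordingly estimated at 48%, with a range from 36% to 60%.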

Compound 3, a percentage reported as activity, at one dose (the size of the read-out at that dose, not a potency): 43.6%
Beside the measured number, compound 3's estimate is 4.4 percentage points above it; the range from low to high includes it.
By their numbers in this assay, from the lowest: compounds 3, 1 and 2 (each within the scatter of the next).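

In this assay, the saturated chain carbon four bonds along the chain from an aromatic nitrogen now has more than one substituent to compare, with hydrogen in place of ethyl giving a number 6.6 percentage points lower from compound 2 to compound 3 (within the scatter) and hydrogen in place of methyl giving a number 4.6 percentage points lower from compound 1 to compound 3 (within the scatter). Removing the 2 carbon atoms of the ethyl therefore leaves the number within the scatter, as does the methyl step a number 2 percentage points higher from compound 1 to compound 2 (within the scatter), so compounds 1, 2 and 3 cannot be ranked and no dependence on chain length can be read from this position. No measurement is available to explain where these values fall.

On these data alone, it remains open whether a much longer chain on the aromatic nitrogen, or a chain ending in a carboxylic acid or an amine, would produce a step beyond the scatter. The read-out at one dose also leaves open whether compounds 1, 2 and 3 would separate into a stronger or weaker effect at other doses.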